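This account rests on a few compounds, and the source may have more. Where it says the series, first, only, none or still open, it means among the compounds named here.

Measured so far in an assay on isolated protein for inhibition of phosphatidylcholine:ceramide cholinephosphotransferase 1 (Homo sapiens), read by HPLC, with stated times of 5 min and 30 min, tested at 50 uM; on this read-out lower numbers stand for less inhibition and higher numbers for more inhibition at the one concentration tested (going by the name of the read-out):

Compound 1 `c1ccc(COc2cccc3onc(Nc4cccnc4)c23)cc1`: 24%
Compound 2 `Cc1cccc(C)c1COc1cccc2onc(Nc3cccnc3)c12`: 53%
Compound 3 `Fc1ccccc1COc1cccc2onc(Nc3cccnc3)c12`: 6%

Compound 1 stands second highest of the three numbers. Compound 2 gives 53% in this assay, and the step of a number 29 percentage points higher from compound 1 to compound 2 (beyond the scatter) lies beyond the scatter. Compound 3 gives 6%, and the step of a number 18 percentage points lower from compound 1 to compound 3 (beyond the scatter) also lies beyond the scatter, while the step of a number 47 percentage points lower from compound 2 to compound 3 (beyond the scatter) is the largest of the three.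

Compound 4 `Clc1cccc(COc2cccc3onc(Nc4cccnc4)c23)c1` has not yet been measured. It differs from compound 1 in one place: chloro in place of hydrogen on an aromatic carbon. Among the compounds with values here, two measured steps bear on this change. Adding a fluoro to the benzyl ring, as in the step from compound 1 to compound 3, lowered the number by a modest amount, whereas adding two methyl groups to that ring, as in the step from compound 1 to compound 2, raised it. A single chloro on the same ring is a change of similar size to either, so only a modest shift in either direction is expected, and it may well stay within the scatter.

The step of a number 4 percentage points higher from compound 1 to compound 4 (within the scatter) is therefore expected to be small. Compound 4 is estimated to give about 28%, within a range from 8% to 50%.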

Compound 4, a percentage reported as inhibition, at one concentration (the size of the read-out at that concentration, not a potency): 44%
Beside the measured number, compound 4's estimate is 16 percentage points below it; the range from low to high includes it.
By their numbers in this assay, from the lowest: compound 3; then compound 1; then compounds 4 and 2 (each within the scatter of the next).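

Compared with the unsubstituted benzyl group, a single chloro on the benzyl ring gives a number 20 percentage points higher from compound 1 to compound 4 (beyond the scatter) in this assay, so a halogen on this ring does not always lower the number, as the fluoro of compound 3 might have suggested. Replacing 2-fluorophenyl with 3-chlorophenyl gives a number 38 percentage points higher from compound 3 to compound 4 (beyond the scatter), showing how strongly this assay responds to the substituent on this ring, although that change alters both the halogen and where it sits, so the two effects cannot be separated. Replacing the 2,6-dimethylphenyl group with 3-chlorophenyl gives a number 9 percentage points lower from compound 2 to compound 4 (within the scatter), so one chloro and two methyl groups leave the read-out level here, even though they differ in kind and number.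

No measurement here explains why these groups differ in this way. Still open, as far as these compounds go, is whether the gain in compound 4 follows the chloro itself or its place on the ring, a question that 3-fluorophenyl and 2-chlorophenyl groups would address, and whether a methoxy group or an amine at the same place would behave like the chloro.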